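Aminomethyl in place of dimethylamino in compound 2

This account rests on a few compounds, and the source may have more. Where it says the series, first, only, none or still open, it means among the compounds named here.

Measured in a physicochemical assay for solubility, read by HPLC, using the shake flask method, in phosphate buffer, with a stated time of 20 h, at pH 6.5; a higher number here means a more soluble compound, a lower number a less soluble compound:
compound 1 `CN1CCN(CC2CCN(c3nccc4[nH]c(-c5ccc(F)c(F)c5)nc34)CC2)CC1`: 195000 nM
compound 2 `CN(C)C1CCN(c2nccc3[nH]c(-c4cccc(OC(F)(F)F)c4)nc23)CC1`: 180000 nM

In this assay compound 2 gives 180000 nM, and compound 1 gives 195000 nM. These two values lie within the scatter of each other, so they cannot be ranked. Compound 3 `NCC1CCN(c2nccc3[nH]c(-c4cccc(OC(F)(F)F)c4)nc23)CC1` keeps the rest of compound 2 but carries aminomethyl in place of dimethylamino on a saturated ring carbon. The same difference reads 4-(dimethylamino)piperidin-1-yl to 4-(aminomethyl)piperidin-1-yl. Within the data shown here, no measured pair shows this change, so the expectation rests mainly on compound 2 at 180000 nM. The expected 1.2-fold lower number from compound 2 to compound 3 (0.08 log units; within the scatter) is small, and no change beyond the scatter is anticipated. For compound 3 the estimated solubility is 150000 nM, with an expected range of 70000 nM to 300000 nM.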

Compound 3, solubility: 200000 nM
Compound 3: the middle estimate sits 1.3-fold (0.12 log units) below what was measured, and the stated range covers the measured number.
By their numbers in this assay, from the lowest: compounds 2, 1 and 3 (each within the scatter of the next).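

In this assay, aminomethyl in place of dimethylamino on a saturated ring carbon gives a 1.1-fold higher number from compound 2 to compound 3 (0.05 log units; within the scatter), so the two groups cannot be ranked at this position. With the rest of compound 2 kept, this change from dimethylamino, with 0 hydrogen-bond donors, to aminomethyl, with 1 hydrogen-bond donor, leaves the reading within the scatter. No measurement available here bears on why the two groups read alike.

The compounds shown leave open whether a hydroxyl or a carboxylic acid on this ring carbon, in place of an amine, would move the number beyond the scatter. From the compounds shown here alone, it also remains open whether the same exchange would read alike with the aromatic group carried by compound 1.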